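Sulfonamide Acetamides: Aryl Swap From Compound 1 to Compound 4

This account rests on a few compounds, and the source may have more. Where it says the series, first, only, none or still open, it means among the compounds named here.

Compound 1 `CCN(CC)C(=O)CN(c1cccc(N(C)C)c1C#N)S(=O)(=O)c1ccc(OC)c(OC)c1` sits at the limit of a functional assay on CHO cells for inhibition of Orexin/Hypocretin receptor type 1 (Homo sapiens), read by FLIPR and calcium flux (on this read-out lower numbers stand for stronger inhibition and higher numbers for weaker inhibition), giving > 10000 nM, which is a limit and not a number. Compound 2 `CCN(CC)C(=O)CN(c1ccc(C)cc1)S(=O)(=O)c1ccc(C(C)(C)C)cc1` likewise returns only a limit in this assay, > 10000 nM. Compound 3 `CCN(C(=O)CN(c1cc2c(C)nsc2cc1Cl)S(=O)(=O)c1ccc(OC)c(OC)c1)c1ccccn1`, with a different aryl on the sulfonamide nitrogen and a pyridyl amide, gives 8 nM in this assay. Going by the values given here, the limit of > 10000 nM in this assay, at which 2 of the 3 values shown sit, holds two of the three values, and no measured pair differs in one place. Compound 4 `CCN(CC)C(=O)CN(c1cc(Cl)ccc1N(C)C)S(=O)(=O)c1ccc(OC)c(OC)c1` carries 5-chloro-2-(dimethylamino)phenyl in place of 2-cyano-3-(dimethylamino)phenyl on a sulfonamide nitrogen, that is 5-chloro-2-(dimethylamino)phenyl in place of 2-cyano-3-(dimethylamino)phenyl on a sulfonamide nitrogen. With compound 1 at a limit, the step cannot be sized from measurement; a gain beyond the scatter is expected, though modest. Compound 4 is expected to give about 4000 nM, between 800 nM and 15000 nM, in this assay. The expected step, an at least 2.5-fold lower number from compound 1 to compound 4 (0.39 log units; beyond the scatter), points toward stronger inhibition.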

Compound 4, half-maximal inhibitory concentration: 4880 nM
Beside the measured number, compound 4's estimate is 1.2-fold (0.09 log units) below it, and the stated range covers the measured number.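

Going by these compounds alone, the sulfonamide nitrogen aryl now gives the only measured single-place step, an at least 2.0-fold lower number from compound 1 to compound 4 (0.31 log units; beyond the scatter), in this assay. With the rest of compound 1 held fixed, 5-chloro-2-(dimethylamino)phenyl brings a number where 2-cyano-3-(dimethylamino)phenyl gave none. The size of the step remains a bound, since the value of compound 1 is a limit: the limit of > 10000 nM in this assay, at which 2 of the 4 values shown sit.

The swap removes the nitrile, adds the chlorine and moves the dimethylamino group together, so these contributions cannot be separated. On these data alone, whether a trifluoromethyl in place of the chlorine or a morpholine in place of the dimethylamino group shifts the number stays open.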